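The compounds below may be only part of what the source reports. "The series", "measured", "known", "first", "only" and "open" are said of these compounds alone.

Compound 2 `CC(C)Cc1csc(N)c1C(=O)c1ccc(Cl)cc1` gives 1% in an assay on CHO cells for displacement of a labelled ligand from adenosine receptor A1 (Homo sapiens), read by scintillation counting, tested at 10 uM (on this read-out lower numbers stand for less inhibition and higher numbers for more inhibition at the one concentration tested (going by the name of the read-out)), level with compound 1 `Cc1csc(N)c1C(=O)c1ccc(Cl)cc1`, which gives 1%. Compound 3 `CC(C)(C)c1csc(N)c1C(=O)c1ccc(Cl)cc1` is still unmeasured. The change from compound 2 to compound 3 is tert-butyl in place of isobutyl on an aromatic carbon. Within the data shown here, the one measured step that bears on it, no change at the digits printed from compound 1 to compound 2 (within the scatter), added a whole isobutyl group on an aromatic carbon of the shared core without moving the read-out, so both measured compounds sit near the bottom of the scale. Rearranging that same group is therefore expected to give a step of no change at the digits printed from compound 2 to compound 3 (within the scatter), none beyond the scatter. Compound 3 is estimated at 1%, between 0% and 10%.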

Compound 3, a percentage reported as inhibition, at one concentration (the size of the read-out at that concentration, not a potency): 1%
For compound 3 middle estimate and measured number coincide at the digits printed, and the stated range covers the measured number.
By their numbers in this assay, from the lowest: compounds 1, 2 and 3 (each within the scatter of the next).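

In this assay, tert-butyl in place of isobutyl gives no change at the digits printed from compound 2 to compound 3 (within the scatter) on this aromatic carbon, so rejoining the same atoms leaves the read-out where it was. Tert-butyl in place of methyl gives no change at the digits printed from compound 1 to compound 3 (within the scatter) and extends that flat result to a second swap at this position. Nothing available explains why these groups read alike. Going by these compounds, whether an amine or a carboxylic acid on this aromatic carbon would move the read-out remains open. So does whether a change elsewhere on the shared core would lift it from the bottom of the scale.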